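Trading a chlorophenyl for a hydroxyphenyl in compound 1

The source may report more compounds than this note shows. Statements on the series, on what has been measured and on what is new or still open speak of the compounds shown alone.

Compound 1 `O=S(=O)(Nc1ccc(-c2nc3ccccc3o2)cc1)c1cccc(Cl)c1` gives 54000 nM in an assay on cells for inhibition of HSP60/HSP10 (Homo sapiens), with a stated time of 60 min; a lower number here means a stronger inhibitor, a higher number a weaker inhibitor.
Compound 2 `O=S(=O)(Nc1ccc2oc(-c3ccccc3)nc2c1)c1cccc(Cl)c1` reaches only the limit > 100000 nM in this assay.
Compound 3 `O=S(=O)(Nc1ccc2oc(-c3ccccc3)nc2c1)c1ccccc1Cl` likewise reaches only the limit > 100000 nM in this assay.

For the measured compounds named here, compound 1 thus holds the only actual number; the other two results are limits (the limit of > 100000 nM in this assay, at which 2 of the 3 values shown sit). The step that the two limits leave unreadable from compound 2 to compound 3 cannot be read, as both ends are limits. Compound 4 `O=S(=O)(Nc1ccc(-c2nc3ccccc3o2)cc1)c1ccc(O)cc1` arises from compound 1 by the change (4-hydroxyphenyl in place of 3-chlorophenyl on a sulfonyl sulfur). Going by the values given here, no measured step swaps a chlorine for a hydroxy group, so nothing here points to a shift in either direction beyond the scatter. Compound 4 is therefore expected near compound 1, as the step of no change at the digits printed from compound 1 to compound 4 (within the scatter), giving an estimate of 54000 nM within 15000 nM to 200000 nM.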

Compound 4, half-maximal inhibitory concentration: 78000 nM
For compound 4 the middle estimate is 1.4-fold (0.16 log units) below the measured one, within the range that was stated.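

For the compounds shown here, this is the first readable step, and it gives a 1.4-fold higher number from compound 1 to compound 4 (0.16 log units; within the scatter) in this assay. On the sulfonyl sulfur, 4-hydroxyphenyl and 3-chlorophenyl therefore cannot be told apart here, even though the entering group carries a hydrogen-bond donor and acceptor that the leaving group lacks. Compound 4 also gives an actual number rather than a limit, unlike the two results whose step cannot be read: the limit of > 100000 nM in this assay, at which 2 of the 4 values shown sit.

As far as these compounds go, this step changes both the substituent and its numbered place on the ring, so the contribution of each stays open. Also open, from the compounds shown here alone, is how 3-hydroxyphenyl, 4-chlorophenyl, or a phenyl ring bearing an amine or a carboxylic acid would read.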